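This account rests on a few compounds, and the source may have more. Where it says the series, first, only, none or still open, it means among the compounds named here.

Values so far in a functional assay on HeLa cells (Homo sapiens) for cytotoxicity, read by WST assay, with a stated time of 48 h; a higher number here means a weaker inhibitor, a lower number a stronger inhibitor
- compound 1 `CCCCCC/C=C/C[C@H]1C[C@@H]([C@@H](O)c2ccccc2)CO[C@@H]1c1ccccc1` gives 7400 nM
- compound 2 `Oc1ccccc1/C=C/C[C@H]1C[C@@H]([C@@H](O)c2ccccc2)CO[C@@H]1c1ccccc1` gives 21800 nM
- compound 3 `COc1cccc(/C=C/C[C@H]2C[C@@H]([C@@H](O)c3ccccc3)CO[C@@H]2c2ccccc2)c1` gives 10900 nM

Compound 3 cannot be separated from either neighbour: the data show a 1.5-fold higher number from compound 1 to compound 3 (0.17 log units; within the scatter) and a 2.0-fold lower number from compound 2 to compound 3 (0.30 log units; within the scatter) here. Only a 2.9-fold higher number from compound 1 to compound 2 (0.47 log units; beyond the scatter) stands clear of the scatter, and it is modest.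

Compound 4 `C=CC[C@H]1C[C@@H]([C@@H](O)c2ccccc2)CO[C@@H]1c1ccccc1` has vinyl in place of 2-(3-methoxyphenyl)ethenyl on a saturated chain carbon bound to a saturated ring carbon. The three measured steps only exchange one chain end for another, and none removes the end group as this change does, so they guide the expectation only loosely. The largest of them, a 2.9-fold higher number from compound 1 to compound 2 (0.47 log units; beyond the scatter), sets the likely scale. A modest step towards a higher number is therefore expected in this assay, though the direction is not secured by the data. The estimated move is a 2.2-fold higher number from compound 3 to compound 4 (0.34 log units; beyond the scatter) as a working figure. For compound 4 the expected value is 24000 nM, with an estimated range from 9000 nM to 60000 nM for now.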

Compound 4, half-maximal inhibitory concentration: 25400 nM
Compound 4: middle estimate off by 1.1-fold (0.02 log units), on the low side, within the range that was stated.
By their numbers in this assay, from the lowest: compounds 1, 3, 2 and 4 (each within the scatter of the next, the first and the last beyond it).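

In this assay this position tolerates more than an exchange of chain ends: cutting the end back to vinyl still leaves a measurable number, and the step from the aromatic end of compound 3 is beyond the scatter (a 2.3-fold higher number from compound 3 to compound 4 (0.37 log units; beyond the scatter)). The step from the group of 8 heavy atoms in compound 1 is also beyond the scatter (a 3.4-fold higher number from compound 1 to compound 4 (0.54 log units; beyond the scatter)), whereas the step from the 2-(2-hydroxyphenyl)ethenyl end of compound 2 is within it (a 1.2-fold higher number from compound 2 to compound 4 (0.07 log units; within the scatter)), so an aromatic ring at the chain end does not by itself separate compound 2 from compound 4. No measurement in hand accounts for these differences.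

Still open, on these data alone, is how an amine, a carboxylic acid or a chain longer than hexyl at this chain end would read. As far as these compounds go, the contribution of the phenyl groups and the hydroxyl on the shared core also remains open, as all four compounds keep them.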